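The source may hold more compounds than are shown below. What is called first, only, known or untested is meant among the compounds shown, and "the series" means these compounds.

Measured compounds:
- Compound 1, `NC1=NC2(CCOCC2)N(OCCCOc2cccc(Cl)c2Cl)C(N)=N1`: "not determined" (no result reported) in an assay on isolated protein for inhibition of Dihydrofolate reductase (Homo sapiens), read by spectrophotometry, using NADPH, with stated times of 5 s and 6 min; on this read-out lower numbers stand for stronger inhibition and higher numbers for weaker inhibition
- Compound 2, `NC1=NC2(CCOCC2)N(OCCCOc2ccc(Cl)cc2Cl)C(N)=N1`: 7.46 nM

Compound 2 is the only one of the two with a number in this assay; compound 1 gives none, so nothing can be said about how the two compare. Compound 2 therefore stands alone as the reference point, and its value in this assay is a low one, meaning strong inhibition on this read-out.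

The next compound, compound 3, `NC1=NC2(CCOCC2)N(OCCCOc2ccc(Br)cc2)C(N)=N1`, keeps the shared core of compound 2 and changes only the aryl group at the far end of the chain: 4-bromophenyl in place of 2,4-dichlorophenyl on an oxygen on a saturated carbon. Among the measured compounds shown here, no step between measured compounds is available to show what such a swap does here, so the expectation rests on the change itself. Since the group that leaves and the group that enters are both single six-membered aromatic rings carrying halogen, the step is expected to be small, at most modestly toward weaker inhibition, and quite possibly within the scatter: the expected step is a 1.5-fold higher number from compound 2 to compound 3 (0.17 log units; within the scatter). Compound 3 is thus estimated at 11 nM, with a range from 4 nM to 30 nM.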

Compound 3, half-maximal inhibitory concentration: 32.5 nM
Compound 3: the middle estimate sits 3.0-fold (0.47 log units) below what was measured; measured number outside the range, above it.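

Among the compounds shown here, with no number for compound 1, any step involving it cannot be read, which makes this the only readable step at the far end of the chain: in this assay, placing 4-bromophenyl where 2,4-dichlorophenyl stood, on an oxygen on a saturated carbon, gives a 4.4-fold higher number from compound 2 to compound 3 (0.64 log units; beyond the scatter). This shows that the value responds to the aryl group at this place, as the step lies beyond the usual scatter even though both groups are a single six-membered aromatic ring of carbon with halogen on it, no hydrogen-bond donors or acceptors and no net charge. Nothing available here accounts for the size or direction of this step, so it stands as an observation only.

The one step swaps the kind of halogen and changes the number of halogens at once, so the compounds shown leave open which of these matters, a question that a 4-chlorophenyl group at the same place could help to separate. Also open, as far as these compounds go, is how the value would respond to an unsubstituted phenyl ring or a longer chain leading to the ring.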